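The compounds below may be only part of what the source reports. "The series", "measured", "known", "first", "only" and "open" are said of these compounds alone.

Compound 1 `CCN(CC)C(=O)C(C)N1CCN(S(=O)(=O)c2ccc(C(C)(C)C)cc2)CC1` gives only a limit in an ADME assay on HepG2 cells (Homo sapiens) for inhibition, with a stated time of 48 h (a lower number here means that less compound is needed, a higher number that more compound is needed for the effect), > 40000 nM. Compound 2 `CC(C(=O)N1C[C@H]2CCC[C@H]2C1)N1CCN(S(=O)(=O)c2ccc(C(C)(C)C)cc2)CC1` also gives only a limit, > 40000 nM. Compound 3 `CC(C(=O)N1CCCc2ccccc21)N1CCN(S(=O)(=O)c2ccc(C(C)(C)C)cc2)CC1` likewise gives only a limit, > 40000 nM.

Compound 1 therefore stands at the ceiling of the readable range, as do the other two: all three values sit at the limit of > 40000 nM in this assay, at which 3 of the 3 values shown sit. Among the measured compounds the changes are a step that the two limits leave unreadable from compound 1 to compound 2, a step that the two limits leave unreadable from compound 1 to compound 3 and a step that the two limits leave unreadable from compound 2 to compound 3; each is unreadable in size and direction, since both ends are limits.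

Compound 4 `CC(C(=O)N1Cc2ccccc2C1)N1CCN(S(=O)(=O)c2ccc(C(C)(C)C)cc2)CC1` is not yet measured. It differs from compound 1 by a group of 9 heavy atoms (8 carbon, 1 nitrogen; one five-membered non-aromatic ring with 1 hetero atom, one six-membered aromatic ring of carbon only) in place of a group of 5 heavy atoms (4 carbon, 1 nitrogen; no ring), on a carbonyl carbon. Among the measured compounds shown here, the steps that bear on this change are those from compound 1 to compound 2 and from compound 1 to compound 3, where the carbonyl substituent is also replaced by a ring-containing group; neither gave a readable number. The expectation for compound 4 is thus a step that the limit leaves unreadable from compound 1 to compound 4, which most likely again ends at a limit. The estimate for compound 4 in this assay is 60000 nM, expected to lie between 25000 nM and 200000 nM.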

Compound 4, half-maximal effective concentration: > 40000 nM
Compound 4 ended at the assay's limit (the forecaster's own chance of this, stated with the estimate: 85%); the middle value does not contradict the limit.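

Compound 4 gives only a limit in this assay, > 40000 nM, so its steps to compound 1, compound 2 and compound 3 cannot be read: the limit of > 40000 nM in this assay, at which 4 of the 4 values shown sit.

The compounds shown leave open whether any group on this carbonyl carbon gives a readable value in this assay.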